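The source may report more compounds than this note shows. Statements on the series, on what has been measured and on what is new or still open speak of the compounds shown alone.

Measured in an ADME assay on MDBK cells (Bos taurus) for cytotoxicity, read by MTT assay, with a stated time of 96 h; on this read-out lower numbers stand for higher toxicity in this test and higher numbers for lower toxicity in this test:
compound 1 `N#Cc1ccc(NC(=S)Nc2cccc(C(F)(F)F)c2)cc1`: 10000 nM
compound 2 `Fc1ccc(NC(=S)Nc2cccc(C(F)(F)F)c2)cc1`: 41000 nM
compound 3 `CCOC(=O)c1ccc(NC(=S)Nc2cccc(C(F)(F)F)c2)cc1`: 64000 nM

Compound 2 stands at the high end of these numbers, with a 1.6-fold higher number from compound 2 to compound 3 (0.19 log units; within the scatter) and a 4.1-fold higher number from compound 1 to compound 2 (0.61 log units; beyond the scatter). Compound 4 `Fc1cccc(NC(=S)Nc2cccc(C(F)(F)F)c2)c1` has the same atoms joined differently: 3-fluorophenyl in place of 4-fluorophenyl on an amide-type nitrogen. The measured steps all exchange one group for another, the largest being a 6.4-fold higher number from compound 1 to compound 3 (0.81 log units; beyond the scatter), and none of them moves the fluoro group, so they give only a loose guide. No change beyond the scatter is therefore expected, and the estimated step is a 1.2-fold lower number from compound 2 to compound 4 (0.07 log units; within the scatter). For compound 4 the expected value is 35000 nM, with an estimated range from 14000 nM to 80000 nM.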

Compound 4, half-maximal cytotoxic concentration: 10000 nM
For compound 4 the middle estimate is 3.5-fold (0.54 log units) above the measured one, outside the stated range (below it).
By their numbers in this assay, from the lowest: compounds 1 and 4 (each within the scatter of the next); then compounds 2 and 3 (each within the scatter of the next).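

In this assay, 3-fluorophenyl in place of 4-fluorophenyl on an amide-type nitrogen gives a 4.1-fold lower number from compound 2 to compound 4 (0.61 log units; beyond the scatter), a step that keeps every atom and only moves the fluoro group. Going by these compounds alone, the earlier steps all exchanged one group for another, so this is the first sign that where the fluoro group sits on this ring counts, not only which group is present. Nothing measured here bears on why the move has this result.

On these data alone, whether a chloro group or an amine, placed as the fluoro group is in 3-fluorophenyl, would give a similar number remains open. So does whether moving the nitrile or the ethoxycarbonyl group would shift the number in the same way.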